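The source may report more compounds than this note shows. Statements on the series, on what has been measured and on what is new or still open speak of the compounds shown alone.

Two compounds share a common core and differ only in what sits on a nitrogen on an aromatic ring. Compound 1 `COc1cc(/C=C/C(=O)c2cccc(NC(=O)c3ccc(Cl)cc3)c2)ccc1O` carries a (4-chlorophenyl)carbonyl group there, and in a functional assay on HUVEC cells (Homo sapiens) for inhibition, tested at 10 ug/mL (on this read-out higher numbers stand for a stronger effect at the one concentration tested and lower numbers for a weaker effect), compound 1 gives 66%. Compound 2 `COc1cc(/C=C/C(=O)c2cccc(N)c2)ccc1O` carries a plain hydrogen instead, and in this assay compound 2 gives 90%. Within the data shown here, that single change produced a number 24 percentage points higher from compound 1 to compound 2 (beyond the scatter), so compound 2 stands highest of the two measured numbers, with compound 1 as its only neighbour.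

Compound 3 `COc1cc(/C=C/C(=O)c2cccc(NC(C)=O)c2)ccc1O` has not yet been measured. Relative to compound 2 it shows (acetyl in place of hydrogen on a nitrogen on an aromatic ring). Among the measured compounds shown here, the only step bearing on this is the one from compound 1 to compound 2, where removing an acyl group from this nitrogen raised the read-out beyond the scatter. Adding a smaller acyl group back is therefore expected to move this assay downward, most likely by a modest amount, giving a number 14 percentage points lower from compound 2 to compound 3 (beyond the scatter). For compound 3 the expected value is 76%, within a range of 58% to 92%.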

Compound 3, a percentage reported as inhibition, at one concentration (the size of the read-out at that concentration, not a potency): 32%
Compound 3: middle estimate off by 44 percentage points, on the high side, and the stated range ends above it.
By their numbers in this assay, from the lowest: compound 3; then compound 1; then compound 2.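

In this assay, placing acetyl on the nitrogen gives a number 58 percentage points lower from compound 2 to compound 3 (beyond the scatter), so a second acyl group also lowers the read-out, and the free amino compound stays the highest of the three. The drop does not follow the size of the added group: exchanging 4-chlorophenyl for methyl on the carbonyl carbon gives a number 34 percentage points lower from compound 1 to compound 3 (beyond the scatter), which shows that the group on that carbonyl matters and that the smaller one gives the lower number here. Nothing shown explains why the read-out moves this way.

From the compounds shown here alone, it remains open where a propanoyl chain or an unsubstituted benzoyl group would fall relative to these two acyl groups. A simple methyl on the nitrogen would show whether the fall requires the carbonyl.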